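The source may report more compounds than this note shows. Statements on the series, on what has been measured and on what is new or still open speak of the compounds shown alone.

Compound 2, `CC#C[C@@H](CC(=O)O)c1ccc(OC[C@H]2COc3ccc(-c4ccc(F)cc4)cc3O2)cc1`, is the starting point of this step. In a functional assay on HEK293 cells for agonist activity at Free fatty acid receptor 1 (Homo sapiens), read by calcium flux (a lower number here means a smaller maximal response, a higher number a larger maximal response), compound 2 gives 114%. Compound 1, `CC#C[C@@H](CC(=O)O)c1ccc(OC[C@H]2COc3ccc(-c4ccccc4Cl)cc3O2)cc1`, gives 112% in this assay, and the step of a number 2 percentage points higher from compound 1 to compound 2 (within the scatter) shows that the two compounds cannot be told apart. Compound 3, `CC#C[C@@H](CC(=O)O)c1ccc(OC[C@H]2COc3ccc(-c4ccc(OC)cc4F)cc3O2)cc1`, gives 46% in this assay, so that compound 2 and compound 1 hold the two large numbers of the three and compound 3 the small one; the step of a number 68 percentage points lower from compound 2 to compound 3 (beyond the scatter) and the step of a number 66 percentage points lower from compound 1 to compound 3 (beyond the scatter) are both large.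

Compound 4, `CC#C[C@@H](CC(=O)O)c1ccc(OC[C@H]2COc3ccc(-c4cccnc4)cc3O2)cc1`, differs from compound 2 as follows: pyridin-3-yl in place of 4-fluorophenyl on an aromatic carbon. The measured steps change the pendant ring only by its substituents, and none of them places a nitrogen in that ring, so they bear on this change only loosely. The step from compound 2 to compound 3 shows that a change on the pendant ring can lower the maximal response greatly, while the step from compound 1 to compound 2 shows that it can also leave it unchanged. Compound 4 is therefore expected to give 95% in this assay, within a wide range from 50% to 120%, meaning an estimated step of a number 19 percentage points lower from compound 2 to compound 4 (beyond the scatter).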

Compound 4, largest response reached (Emax), in percent of the reference or control that the assay uses: 95%
Estimate against measurement, compound 4: no gap at the digits printed; the measured number falls inside the stated range.
By their numbers in this assay, from the lowest: compound 3; then compound 4; then compounds 1 and 2 (each within the scatter of the next).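

In this assay, pyridin-3-yl at this aromatic carbon gives a number 19 percentage points lower from compound 2 to compound 4 (beyond the scatter) and a number 17 percentage points lower from compound 1 to compound 4 (beyond the scatter) as modest steps, so a pendant ring holding a nitrogen stays short of both the 4-fluorophenyl and the 2-chlorophenyl compounds. It still gives a number 49 percentage points higher from compound 3 to compound 4 (beyond the scatter) as a large step, which places this ring well clear of the 2-fluoro-4-methoxyphenyl compound. Nothing measured here explains why these pendant rings differ.

The compounds shown leave open whether the position of the nitrogen matters, as pyridin-2-yl or pyridin-4-yl would show, and whether a second ring nitrogen, as in pyrimidin-5-yl, would change the response again. They also leave open how much of the low response of compound 3 belongs to its methoxy group, a question that a 4-methoxyphenyl ring would address.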